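Sulfanyl-Linked Substituents on a Purine Riboside Core

The compounds below may be only part of what the source reports. "The series", "measured", "known", "first", "only" and "open" are said of these compounds alone.

Measured compounds:
compound 1, `O=[N+]([O-])c1cccc2c1CN(c1ncnc3c1nc1n3[C@@H]3O[C@H](CO1)[C@@H](O)[C@H]3O)CC2`, 1740000 nM
compound 2, `CCCCCNc1ncnc2c1ncn2[C@@H]1O[C@H](CO)[C@@H](O)[C@H]1O`, 13500 nM
compound 3, `OC[C@H]1O[C@@H](n2cnc3c(SC4CCCCC4)ncnc32)[C@H](O)[C@@H]1O`, 6310 nM

In an assay on isolated protein for binding affinity to Equilibrative nucleoside transporter 1 (Homo sapiens) (a higher number here means a weaker inhibitor, a lower number a stronger inhibitor), compound 2 gives 13500 nM, the second highest of the three numbers. Its nearest neighbour is compound 3, which gives 6310 nM; the step between them is a 2.1-fold lower number from compound 2 to compound 3 (0.33 log units; beyond the scatter), a modest move that is nonetheless beyond the scatter. Far away stands compound 1, which gives 1740000 nM, the weakest of the three by a wide margin.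

The compound not yet measured is compound 4, `Cc1ccc(CSc2ncnc3c2ncn3[C@@H]2O[C@H](CO)[C@@H](O)[C@H]2O)cc1`. It differs from compound 2 in one place: (4-methylbenzyl)sulfanyl in place of pentylamino on an aromatic carbon

Going by the values given here, only one measured step bears on this change, the replacement of pentylamino by a sulfanyl-linked group in a 2.1-fold lower number from compound 2 to compound 3 (0.33 log units; beyond the scatter). That step lowered the number modestly. Among the compounds with values here, compound 4 also carries a sulfanyl link, but the group that enters is (4-methylbenzyl)sulfanyl rather than cyclohexylsulfanyl, and no measured pair shows the effect of that aromatic ring on this core. The direction is therefore expected to follow compound 3, downward, with the size uncertain. Compound 4 is estimated to give 500 nM, within 50 nM to 5000 nM, which would mean an expected step of a 27-fold lower number from compound 2 to compound 4 (1.43 log units; beyond the scatter).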

Compound 4, half-maximal inhibitory concentration: 457 nM
The estimate for compound 4 lay 1.1-fold (0.04 log units) above the measured number, and the stated range covers the measured number.
By their numbers in this assay, from the lowest: compound 4; then compound 3; then compound 2; then compound 1.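

In this assay, cyclohexylsulfanyl in place of pentylamino had given only a modest move (a 2.1-fold lower number from compound 2 to compound 3 (0.33 log units; beyond the scatter)), whereas (4-methylbenzyl)sulfanyl at the same aromatic carbon gives a large one (a 30-fold lower number from compound 2 to compound 4 (1.47 log units; beyond the scatter)). With the sulfur kept, exchanging cyclohexyl for 4-methylbenzyl still gives a large move (a 14-fold lower number from compound 3 to compound 4 (1.14 log units; beyond the scatter)), which shows that the sulfanyl link does not by itself set the number at this position and that the group carried on the sulfur strongly changes it. No measurement at hand explains this difference between the two groups on the sulfur.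

The compounds shown do not separate the contributions of the aromatic ring, its methyl group and the carbon joining that ring to the sulfur, so an unsubstituted benzyl, a chloro-substituted benzyl or a pentyl chain on the sulfur would be needed to tell them apart. They also leave open whether the same 4-methylbenzyl group joined through an amine nitrogen instead of sulfur would lower the number as far, which would show how much depends on the linking atom.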